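The source may report more compounds than this note shows. Statements on the series, on what has been measured and on what is new or still open speak of the compounds shown alone.

Measured compounds:
compound 1 `Cc1ccc(Nc2nc(Cl)nc3c2ncn3Cc2ccc(C(=O)Nc3ccccc3N)cc2)cc1` — in a functional assay on HCT-116 cells (Homo sapiens) for antiproliferative activity, read by CCK-8 assay, with a stated time of 72 h, tested at 2 uM (on this read-out higher numbers stand for a stronger effect at the one concentration tested and lower numbers for a weaker effect), compound 1 gives 76.3%
compound 2 `Nc1ccccc1NC(=O)c1ccc(COCNc2nc(Nc3ccccc3)c3ncn(C4CCCC4)c3n2)cc1` — compound 2 gives 75.2%
compound 3 `CCCCn1cnc2c(Nc3ccccc3)nc(NCOCc3ccc(C(=O)Nc4ccccc4N)cc3)nc21` — compound 3 gives 72.9%

Compound 1 carries the highest of the three numbers, but its gaps to compound 2 and to compound 3 both lie within the scatter, so the three read as one level. Among the compounds with values here, the only step between measured compounds, a number 2.3 percentage points lower from compound 2 to compound 3 (within the scatter), concerns a butyl in place of cyclopentyl on an aromatic nitrogen and does not touch the site changed here.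

Compound 4 `Nc1ccccc1NC(=O)c1ccc(Cn2cnc3c(Nc4cccc(Cl)c4)nc(Cl)nc32)cc1` differs from compound 1 by 3-chlorophenyl in place of 4-methylphenyl on a nitrogen on an aromatic ring. Within the data shown here, no measured step covers an exchange of the aryl group on this nitrogen, so no step beyond the scatter is expected, a number 2.3 percentage points lower from compound 1 to compound 4 (within the scatter). Compound 4 is therefore estimated at 74%, with a range from 62% to 84%.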

Compound 4, a percentage reported as inhibition, at one concentration (the size of the read-out at that concentration, not a potency): 56.2%
Compound 4: the middle estimate sits 17.8 percentage points above what was measured; measured number outside the range, below it.
By their numbers in this assay, from the lowest: compound 4; then compounds 3, 2 and 1 (each within the scatter of the next).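

The aryl group on this nitrogen matters in this assay: with 3-chlorophenyl in place of 4-methylphenyl, the read-out gives a number 20.1 percentage points lower from compound 1 to compound 4 (beyond the scatter), although the two groups have the same count of heavy atoms and neither carries hydrogen-bond donors or acceptors. The earlier compounds shown here showed only a step at another site, one that stayed within the scatter. Nothing at hand accounts for this drop.

Going by these compounds, whether the drop follows the chlorine or the place of the substituent on the ring remains open. A 4-chlorophenyl or 3-methylphenyl group on this nitrogen would separate the two.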